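Methylsulfonyl in place of tert-butyl: expectation for compound 4

This account rests on a few compounds, and the source may have more. Where it says the series, first, only, none or still open, it means among the compounds named here.

Notes on the shared core of compound 3 `CCCS(=O)(=O)Nc1ccc(F)c(C(=O)c2n[nH]c3ncc(-c4ccc(C(C)(C)C)cc4)cc23)c1F`. Within the data shown here, in an assay for binding affinity to dual specificity mitogen-activated protein kinase kinase 4 (Homo sapiens), read by KINOMEscan, tested at 100 nM (on this read-out lower numbers stand for a stronger effect and higher numbers for a weaker effect at the one concentration tested), compound 3 gives 46%, the highest of the three numbers so far, although a number 1 percentage points higher from compound 2 to compound 3 (within the scatter) lies within the scatter; compound 2 `CCCS(=O)(=O)Nc1ccc(F)c(C(=O)c2n[nH]c3ncc(-c4ccc(Cl)c(Cl)c4)cc23)c1F` gives 45%. Compound 1 `CCCS(=O)(=O)Nc1ccc(F)c(C(=O)c2n[nH]c3ncc(-c4ccc(OC)cc4)cc23)c1F` gives 4.2%, and the two steps away from it, a number 40.8 percentage points higher from compound 1 to compound 2 (beyond the scatter) and a number 41.8 percentage points higher from compound 1 to compound 3 (beyond the scatter), are both large and run the same way.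

Compound 4 `CCCS(=O)(=O)Nc1ccc(F)c(C(=O)c2n[nH]c3ncc(-c4ccc(S(C)(=O)=O)cc4)cc23)c1F` differs from compound 3 by methylsulfonyl in place of tert-butyl on an aromatic carbon. Among the measured compounds shown here, no measured step carries this exact change. What bears on it is that the group at this place matters greatly in this series: the methoxy of compound 1 stands far from the tert-butyl of compound 3, as a number 41.8 percentage points higher from compound 1 to compound 3 (beyond the scatter) shows, while the dichloro pattern of compound 2 sits with the tert-butyl. The incoming group brings acceptors, as the methoxy of compound 1 does, so a downward step beyond the scatter is plausible, but with a single such example its size is uncertain and the range must stay wide.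

Compound 4 is expected to give 25% in this assay, within 3% to 65%. This corresponds to an expected step of a number 21 percentage points lower from compound 3 to compound 4 (beyond the scatter).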

Compound 4, a percentage reported as activity, at one concentration (the size of the read-out at that concentration, not a potency): 1.5%
Beside the measured number, compound 4's estimate is 23.5 percentage points above it; the whole stated range lies above it.
By their numbers in this assay, from the lowest: compounds 4 and 1 (each within the scatter of the next); then compounds 2 and 3 (each within the scatter of the next).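

In this assay, methylsulfonyl in place of tert-butyl gives a number 44.5 percentage points lower from compound 3 to compound 4 (beyond the scatter), and 4-(methylsulfonyl)phenyl in place of 3,4-dichlorophenyl gives a number 43.5 percentage points lower from compound 2 to compound 4 (beyond the scatter), so the low number of compound 1 is no longer a single case at this position. Methylsulfonyl in place of methoxy gives a number 2.7 percentage points lower from compound 1 to compound 4 (within the scatter), which leaves the two groups indistinguishable here and divides the four compounds into two sets: compounds 1 and 4, whose groups carry hydrogen-bond acceptors, and compounds 2 and 3, whose groups do not. No supporting data are available to explain this division.

Going by these compounds, it remains open whether an amine, a carboxylic acid or a nitrile on this aromatic carbon would join compounds 1 and 4 or compounds 2 and 3. On these data alone, a longer chain in place of the methyl of the methylsulfonyl is equally open.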